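The source may report more compounds than this note shows. Statements on the series, on what has been measured and on what is new or still open speak of the compounds shown alone.

Within the data shown here, compound 3 `O=C(Nc1cccc(-n2cc(-c3ccncc3)c(-c3ccc(Cl)c(O)c3)n2)c1)Nc1ccc(Cl)c(Cl)c1` stands at the highest of the three numbers measured so far: in a functional assay on OVCAR-5 cells (Homo sapiens) for inhibition, read by sulforhodamine B assay, with a stated time of 48 h (a lower number here means a stronger inhibitor of growth, a higher number a weaker inhibitor of growth), compound 3 gives 2400 nM. Its closest neighbour is compound 2 `COc1cc(-c2nn(-c3cccc(NC(=O)Nc4ccc(Cl)c(Cl)c4)c3)cc2-c2ccncc2)ccc1Cl`, which gives 2130 nM; the step of a 1.1-fold higher number from compound 2 to compound 3 (0.05 log units; within the scatter) is within the scatter. Compound 1 `COc1cc(-c2nn(-c3cccc(NC(=O)Nc4cc(C(F)(F)F)cc(C(F)(F)F)c4)c3)cc2-c2ccncc2)ccc1Cl` gives 937 nM, the lowest number of the three.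

Compound 4 `O=C(Nc1cccc(-n2cc(-c3ccncc3)c(-c3ccc(Cl)c(O)c3)n2)c1)Nc1ccc(Cl)c(C(F)(F)F)c1` is not yet measured. It differs from compound 3 by trifluoromethyl in place of chloro on an aromatic carbon. Among the measured compounds shown here, no measured step covers this exact change in one place. For the measured compounds named here, the only guide is the pair compound 1 and compound 2, which differ at the urea aryl in more than one group, so their values can only be taken at face value: compound 1 gives 937 nM where compound 2 gives 2130 nM, the aryl bearing trifluoromethyl groups sitting at the lower number. On that basis a modest move to a lower number is expected for compound 4, the step of a 1.5-fold lower number from compound 3 to compound 4 (0.18 log units; within the scatter) being the estimate. Compound 4 is expected at 1600 nM, with a range from 700 nM to 3600 nM.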

Compound 4, concentration for 50% growth inhibition: 1570 nM
Beside the measured number, compound 4's estimate is 1.0-fold (0.01 log units) above it; measured number inside the range.
By their numbers in this assay, from the lowest: compounds 1, 4, 2 and 3 (each within the scatter of the next, the first and the last beyond it).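

In this assay, trifluoromethyl in place of chloro on an aromatic carbon, ortho to a chloro group, gives a 1.5-fold lower number from compound 3 to compound 4 (0.18 log units; within the scatter), so at this position 4 heavy atoms can replace 1 without a change that can be told from the scatter. Among these compounds, this is the first change on the 3,4-dichlorophenyl group that can be read in one place; the only earlier step, a 1.1-fold higher number from compound 2 to compound 3 (0.05 log units; within the scatter), lay at the oxygen on the other aromatic ring. No measurement available gives a reason for this result.

On these data alone, whether this position also accepts an amine, a carboxylic acid or a longer chain in place of chloro remains open. Also open, as far as these compounds go, is whether the same exchange reads alike when the oxygen carries methyl, as in compound 2.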